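A few compounds are considered here, and "the series" means these few. Any claim that something is new, unique, unknown or untested is made for them only; others in the source may bear on it.

Measured compounds:
compound 1, `CNC(=O)c1cnc(C(=O)CCc2ccc(COc3ccccc3)cc2)o1`, with 3.6 nM in an assay for inhibition of Fatty-acid amide hydrolase 1 (Rattus norvegicus); on this read-out lower numbers stand for stronger inhibition and higher numbers for weaker inhibition;
compound 2, `NC(=O)c1cnc(C(=O)CCc2ccc(Oc3ccccc3)cc2)o1`, with 6.6 nM in this assay;
compound 3, `COC(=O)c1cc(-c2cnc(C(=O)CCc3ccc(-c4ccccc4)cc3)o2)ccn1`, with 1.5 nM in this assay.

Compound 2 gives the highest of the three numbers. Its nearest neighbour is compound 1, whose number is lower by a margin that stays within the usual scatter, so the two cannot be told apart. Compound 3 stands furthest away, with a number low enough that the gap to compound 2 lies beyond the scatter.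

The unmeasured compound 4, `O=C(CCc1ccc(Oc2ccccc2)cc1)c1ncc(I)o1`, is drawn from compound 2 by one change: iodo in place of carbamoyl on an aromatic carbon. The carbamoyl that leaves carries a hydrogen-bond donor and acceptor; the iodo that enters carries neither. Going by the values given here, no pair of measured compounds differs in this way, so the size of the step cannot be read from the data.

The account expects a step upward from compound 2 to compound 4 in this assay of a 3.0-fold higher number from compound 2 to compound 4 (0.48 log units; beyond the scatter), meaning weaker inhibition, though the step could still fall within the scatter. On that basis compound 4 is estimated at 20 nM in this assay, with a likely range from 5 nM to 80 nM.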

Compound 4, inhibition constant: 10 nM
Compound 4: the middle estimate sits 2.0-fold (0.30 log units) above what was measured; low and high end bracket the measured number.
By their numbers in this assay, from the lowest: compound 3; then compounds 1, 2 and 4 (each within the scatter of the next, the first and the last beyond it).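

In this assay, going by these compounds alone, the change from 5-carbamoyl-1,3-oxazol-2-yl to 5-iodo-1,3-oxazol-2-yl gives a 1.5-fold higher number from compound 2 to compound 4 (0.18 log units; within the scatter) and so provides the first reading of a single change at this position, on an aromatic carbon next to the ring oxygen. The carbamoyl, with its hydrogen-bond donor and acceptor, gives way here to a single iodine with no step that can be told from the scatter, so in this pair neither the donor, nor the acceptor, nor the three heavy atoms of the carbamoyl are shown to be needed to keep the number in the same range. The compounds shown offer no independent measurement that could explain why this step stays so small.

Within the data shown here, one pair gives only one step, so it remains open whether a carboxylic acid, a nitrile, a methyl ester or a plain hydrogen at this position would give a number in the same range as the carbamoyl and the iodo. Going by these compounds, it also remains open whether iodo at this position would give a similar step on the core of compound 1 or compound 3, where other groups occupy the rest of the molecule.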